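Series notes: amine and azole variants on the benzamide ring

This account rests on a few compounds, and the source may have more. Where it says the series, first, only, none or still open, it means among the compounds named here.

Within the data shown here, compound 2 `O=C(c1ccc(-n2cccn2)cc1Cl)N1CCCCc2ccccc21` gives 8.8 nM in an assay on HeLa cells for binding affinity to Vasopressin V2 receptor (Homo sapiens) (a higher number here means a weaker inhibitor, a lower number a stronger inhibitor), the larger of the two numbers so far, though its gap to compound 1 `C=CCNc1ccc(C(=O)N2CCCCc3ccccc32)c(Cl)c1` with 5.9 nM lies within the scatter, as the step of a 1.5-fold higher number from compound 1 to compound 2 (0.17 log units; within the scatter) shows. Compound 3 `CC1CCN(c2ccc(C(=O)N3CCCCc4ccccc43)c(Cl)c2)C1` carries 3-methylpyrrolidin-1-yl in place of 1H-pyrazol-1-yl on an aromatic carbon. Among the measured compounds shown here, the only step that bears on this position is the one from compound 1 to compound 2, which stayed within the scatter, so no shift beyond the scatter is expected in this assay. Compound 3 is therefore estimated at 7 nM, with a range of 2.5 nM to 20 nM, a step of a 1.3-fold lower number from compound 2 to compound 3 (0.10 log units; within the scatter).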

Compound 3, half-maximal inhibitory concentration: 51 nM
Estimate against measurement, compound 3: 7.3-fold (0.86 log units) below; the whole stated range lies below it.
By their numbers in this assay, from the lowest: compounds 1 and 2 (each within the scatter of the next); then compound 3.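

This position is not indifferent to its group in this assay: 3-methylpyrrolidin-1-yl gives a 5.8-fold higher number from compound 2 to compound 3 (0.76 log units; beyond the scatter) and also an 8.6-fold higher number from compound 1 to compound 3 (0.94 log units; beyond the scatter), while allylamino and 1H-pyrazol-1-yl had stayed within the scatter of each other. The tolerance seen with compound 1 and compound 2 therefore does not extend to compound 3. Nothing available explains this step.

The compounds shown leave open whether the step follows the methyl group or the non-aromatic ring. Unsubstituted pyrrolidin-1-yl and 3-methyl-1H-pyrazol-1-yl at this position would separate these two readings.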